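The compounds below may be only part of what the source reports. "The series", "measured", "known", "first", "only" and "open" are said of these compounds alone.

Measured so far:
Compound 1 `CC1CCN(C2CCN(S(=O)(=O)c3cccc(C(F)(F)F)c3)CC2)CC1` — > 5000 nM in a functional assay on DLD-1 cells (Homo sapiens) for antiproliferative activity, read by CellTiter-Glo, with a stated time of 72 h; a lower number here means a stronger inhibitor, a higher number a weaker inhibitor
Compound 2 `COc1ccc(-c2cccc(S(=O)(=O)N3CCC(N4CCC(C)CC4)CC3)c2)cc1` — 23 nM
Compound 3 `CC1CCN(C2CCN(S(=O)(=O)c3cccc(-c4ccc(Cl)cc4)c3)CC2)CC1` — 15 nM.

For compound 1 the value in this assay is a limit of the assay rather than a number (the limit of > 5000 nM in this assay, at which 1 of the 3 values shown sits). Compound 4 `CC1CCN(C2CCN(S(=O)(=O)c3ccc(Cl)c(C(F)(F)F)c3)CC2)CC1` carries chloro in place of hydrogen on an aromatic carbon, the trifluoromethyl being kept. The measured steps alter a different place: replacing the trifluoromethyl by a larger group gave an at least 210-fold lower number from compound 1 to compound 2 (2.33 log units; beyond the scatter) and an at least 330-fold lower number from compound 1 to compound 3 (2.52 log units; beyond the scatter), and between compound 2 and compound 3 there was a 1.5-fold lower number from compound 2 to compound 3 (0.19 log units; within the scatter). None of these shows what a single chloro ortho to a kept trifluoromethyl does, so no step beyond the scatter is expected. Compound 4 is estimated to stay near the limit, a number no higher from compound 1 to compound 4 (the limit leaves the size open). Compound 4 is expected at 5000 nM, in a range from 1500 nM to 20000 nM.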

Compound 4, half-maximal inhibitory concentration: 17 nM
The estimate for compound 4 lay 290-fold (2.47 log units) above the measured number, and the stated range ends above it.
By their numbers in this assay, from the lowest: compounds 3, 4 and 2 (each within the scatter of the next). At a limit, above all of these: compound 1.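

In this assay, a single chloro on an aromatic carbon, ortho to a trifluoromethyl group, gave an at least 290-fold lower number from compound 1 to compound 4 (2.46 log units; beyond the scatter). The trifluoromethyl therefore need not give way to a larger group: with it kept, this one added atom brings compound 4 within the scatter of compound 2 and compound 3. The value of compound 1 is a limit of the assay, not a number, so the true size of the step stays open: the limit of > 5000 nM in this assay, at which 1 of the 4 values shown sits.

Going by these compounds, whether a bromo, a methyl or an amine on this carbon would do the same remains open. So does whether a chloro here would add anything to the 4-chlorophenyl of compound 3.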